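The source may report more compounds than this note shows. Statements on the series, on what has been measured and on what is new or still open speak of the compounds shown alone.

Measured in an assay on cells for inhibition of HSP60/HSP10 (Homo sapiens), with a stated time of 60 min; a higher number here means a weaker inhibitor, a lower number a stronger inhibitor:
Compound 1 `O=S(=O)(Nc1ccc2oc(-c3ccccc3)nc2c1)c1cccc(C(F)(F)F)c1`: > 100000 nM
Compound 2 `O=S(=O)(Nc1ccc2oc(-c3ccccc3)nc2c1)c1ccc(F)c(C(F)(F)F)c1`: 69000 nM
Compound 3 `O=S(=O)(Nc1ccc2oc(-c3ccccc3)nc2c1)c1ccc(Cl)cc1`: > 100000 nM

Compound 3 returns only a limit, (the limit of > 100000 nM in this assay, at which 2 of the 3 values shown sit), so its true number is not known. Compound 4 `O=S(=O)(Nc1ccc2oc(-c3ccccc3)nc2c1)c1ccc(Cl)c(C(F)(F)F)c1` is not yet measured; it differs from compound 3 by trifluoromethyl in place of hydrogen on an aromatic carbon. Among the compounds with values here, no measured step introduces a trifluoromethyl group. The closest comparison is an at least 1.4-fold lower number from compound 1 to compound 2 (0.16 log units; that floor lies within the scatter), where fluoro entered a ring already carrying trifluoromethyl and compound 2 reached 69000 nM. The step of an at least 1.6-fold lower number from compound 3 to compound 4 (0.22 log units; that floor lies within the scatter) is therefore expected to be small, if anything toward a stronger inhibitor. Compound 4 is estimated at 60000 nM, between 20000 nM and 150000 nM, with a real chance that this assay again reports only a limit.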

Compound 4, half-maximal inhibitory concentration: > 100000 nM
Compound 4: no number, only a limit (the forecaster's own chance of this, stated with the estimate: 35%); at least 1.6-fold (0.22 log units) between middle value and limit.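

In this assay compound 4 gives > 100000 nM, a limit and not a number, so trifluoromethyl ortho to a chloro group brings no readable gain. Chloro in place of fluoro gives an at least 1.4-fold higher number from compound 2 to compound 4 (0.16 log units; that floor lies within the scatter), so this one readable step does not establish a real loss. The steps to compound 4 from compound 3 and from compound 1 cannot be read, because both ends of each are limits: the limit of > 100000 nM in this assay, at which 3 of the 4 values shown sit.

Going by these compounds, the true strengths of compound 1, compound 3 and compound 4 remain unknown. Also open, on these data alone, is whether an amine or a carboxylic acid in place of the chloro would give a number clear of the limit.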